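Chloro to hydrogen on the aryl ring: expected permeability

This account rests on a few compounds, and the source may have more. Where it says the series, first, only, none or still open, it means among the compounds named here.

Three compounds have been measured in an ADME assay for permeability; a lower number here means that the compound crosses the layer more slowly, a higher number that the compound crosses the layer faster:
compound 1 `CNC(=O)c1cc(C(=O)N[C@H]2[C@@H]3C[C@H](O)C[C@@H]32)n([C@@H](C)c2cccc(Cl)c2)n1` gives 333 nm/s
compound 2 `CNC(=O)c1cc(C(=O)N[C@H]2CC[C@H](O)CC2)n([C@@H](C)c2cccc(Cl)c2)n1` gives 235 nm/s
compound 3 `CNC(=O)c1cc(C(=O)N[C@H]2[C@@H]3C[C@@H](O)C[C@@H]32)n([C@@H](C)c2cccc(Cl)c2)n1` gives 197 nm/s

All three sit close together. The step of a 1.4-fold lower number from compound 1 to compound 2 (0.15 log units; within the scatter) and the step of a 1.7-fold lower number from compound 1 to compound 3 (0.23 log units; within the scatter) are both within the scatter, and so is a 1.2-fold lower number from compound 2 to compound 3 (0.08 log units; within the scatter). For compounds 1 and 3 this is notable because of the fact that compounds 1 and 3 differ only in the configuration as drawn. Compound 2 stands second highest of the three numbers, with compound 3 its nearest neighbour and compound 1 the furthest, both within the scatter, so no order among them can be read.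

Compound 4 `CNC(=O)c1cc(C(=O)N[C@H]2CC[C@H](O)CC2)n([C@@H](C)c2ccccc2)n1` is the next compound and has not yet been measured in this assay. It differs from compound 2 by hydrogen in place of chloro on an aromatic carbon. Going by the values given here, none of the measured steps touches this part of the molecule: all three concern the saturated alcohol-bearing ring on the amide nitrogen or its configuration, and all three were within the scatter. Among the compounds with values here, there is therefore no measured step that predicts the size of this change. Compound 4 is expected to give a number close to that of compound 2, with the step of a 1.2-fold lower number from compound 2 to compound 4 (0.07 log units; within the scatter) expected to stay within the scatter. The estimate for compound 4 is 200 nm/s, with a range from 110 nm/s to 360 nm/s.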

Compound 4, apparent permeability: 80 nm/s
The estimate for compound 4 lay 2.5-fold (0.40 log units) above the measured number, outside the stated range (below it).
By their numbers in this assay, from the lowest: compound 4; then compounds 3, 2 and 1 (each within the scatter of the next).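

Going by these compounds alone, with the change from 3-chlorophenyl to phenyl, this assay gives a 2.9-fold lower number from compound 2 to compound 4 (0.47 log units; beyond the scatter) and so the first step in this set that lies beyond the scatter. The earlier steps all concerned the saturated alcohol-bearing ring on the amide nitrogen or its configuration, and none of them could be read, so this aromatic position is the only place shown where a change separates two compounds in this read-out. Compound 4 now stands lowest of the four, with a single chlorine atom as the whole difference from compound 2, and nothing among the facts at hand accounts for the size of this step.

Going by these compounds, whether only chloro holds the number near that of compound 2, or whether fluoro, methyl or methoxy at the same aromatic carbon would do the same, remains open. Also open, on these data alone, is whether replacing chloro with hydrogen would give a step of similar size in compound 1 or compound 3, which carry a different group on the amide nitrogen.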